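The compounds below may be only part of what the source reports. "The series", "measured", "known", "first", "only" and "open" are said of these compounds alone.

Measured compounds:
- compound 1, `CC1(COc2ccc(OC(F)(F)F)cc2Cl)CCn2cc([N+](=O)[O-])nc2O1`: > 100000 nM
- compound 2, `O=[N+]([O-])c1cn2c(n1)OC(COc1ccc(-c3ccc(OC(F)(F)F)cc3)nn1)CC2`: 42000 nM
- compound 3, `O=[N+]([O-])c1cn2c(n1)OC[C@H](OCc1ccc(-c3ccc(C(F)(F)F)cc3Cl)cn1)C2`: 50000 nM

Of the compounds shown here, three sharing a nitroimidazole-fused core have been tested in an ADME assay on L6 cells (Rattus norvegicus) for cytotoxicity, read by resazurin assay, with a stated time of 72 h; on this read-out higher numbers stand for weaker inhibition and lower numbers for stronger inhibition. Compound 1 reaches only the limit of the assay, giving > 100000 nM; this is a limit, not a number. Compound 2 gives 42000 nM in this assay. Compound 3 gives 50000 nM in this assay, and its value and that of compound 2 sit within the scatter of each other, so no order between them can be read. Of the two numbers shown, compound 3 carries the higher one, but only by a gap inside the scatter.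

Compound 4, `O=[N+]([O-])c1cn2c(n1)OC[C@@H](OCc1ccc(-c3ccc(C(F)(F)F)cc3Cl)cn1)C2`, is yet to be measured in this assay. How it differs from compound 3: the two compounds have the same atoms and bonds and differ only in configuration as drawn: 1 of 1 stereo elements differ; a stereocentre at a saturated ring carbon is drawn R in compound 3 and S in compound 4. With no other change to the molecule, the step is expected to show no shift beyond the scatter in either direction, so the step from compound 3 to compound 4 is estimated as no change at the digits printed from compound 3 to compound 4 (within the scatter). Compound 4 is therefore expected to give about 50000 nM, within a range from 20000 nM to 120000 nM.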

Compound 4, half-maximal inhibitory concentration: 57000 nM
Beside the measured number, compound 4's estimate is 1.1-fold (0.06 log units) below it; low and high end bracket the measured number.
By their numbers in this assay, from the lowest: compounds 2, 3 and 4 (each within the scatter of the next). At a limit, above all of these: compound 1.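

Turning the stereocentre at the saturated ring carbon from R to S gives, in this assay, a 1.1-fold higher number from compound 3 to compound 4 (0.06 log units; within the scatter), so this step leaves no readable difference. Configuration at this position therefore has no effect that can be told apart from the scatter in this assay, something the earlier compounds alone could not show. The comparison is a clean one, with no second change to account for: the fact that compounds 3 and 4 differ only in the configuration as drawn.

As far as these compounds go, whether a different group on the side chain at this ring carbon, such as an amine or a carboxylic acid, would move the value beyond the scatter remains open. Compound 1 stands at a limit, so its place relative to the other compounds cannot be given as a number: the limit of > 100000 nM in this assay, at which 1 of the 4 values shown sits.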